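Dimethylamino Replaces Isobutylamino on the Shared Core

The compounds below may be only part of what the source reports. "The series", "measured", "known", "first", "only" and "open" are said of these compounds alone.

Of the compounds shown here, three sharing one core have been measured in an ADME assay on cells (Homo sapiens) for cytotoxicity, read by polymerase chain reaction, with a stated time of 3 days; on this read-out higher numbers stand for lower toxicity in this test and lower numbers for higher toxicity in this test. Compound 1 `Cc1nc(N)nc(N[C@@H]2C[C@H](CO)[C@@H](O)[C@H]2O)c1-c1nc2ccccc2s1` gives 4000 nM. Compound 2 `Cc1nc(NC(C)(C)C)nc(N[C@@H]2C[C@H](CO)[C@@H](O)[C@H]2O)c1-c1nc2ccccc2s1` gives 12000 nM. Compound 3 `Cc1nc(NCC(C)C)nc(N[C@@H]2C[C@H](CO)[C@@H](O)[C@H]2O)c1-c1nc2ccccc2s1` gives 10000 nM. Among these three numbers compound 3 stands second highest: its number lies within the scatter of that of compound 2, while the step of a 2.5-fold higher number from compound 1 to compound 3 (0.40 log units; beyond the scatter) lies beyond the scatter. The parallel step a 3.0-fold higher number from compound 1 to compound 2 (0.48 log units; beyond the scatter) points the same way, and a 1.2-fold lower number from compound 2 to compound 3 (0.08 log units; within the scatter) stays within the scatter.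

The next compound, compound 4 `Cc1nc(N(C)C)nc(N[C@@H]2C[C@H](CO)[C@@H](O)[C@H]2O)c1-c1nc2ccccc2s1`, is not yet measured. It differs from compound 3 in one place: dimethylamino in place of isobutylamino on an aromatic carbon, on an aromatic carbon of a six-membered aromatic ring with 2 nitrogen, between two ring nitrogen atoms, para to a 1,3-benzothiazol-2-yl group. The measured steps at this position show that putting an alkyl group on this nitrogen went with a higher number, and that exchanging one alkyl for another stayed within the scatter. Among the measured compounds shown here, no measured compound lacks the hydrogen on this nitrogen, so the move to dimethylamino is not directly covered. The expected step is a 1.3-fold lower number from compound 3 to compound 4 (0.10 log units; within the scatter), within the scatter. The estimate for compound 4 in this assay is 8000 nM, with a range from 3000 nM to 20000 nM.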

Compound 4, half-maximal cytotoxic concentration: 18000 nM
Compound 4: the middle estimate sits 2.3-fold (0.35 log units) below what was measured, within the range that was stated.
By their numbers in this assay, from the lowest: compound 1; then compounds 3, 2 and 4 (each within the scatter of the next).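

In this assay, this aromatic carbon now carries a group whose nitrogen has no hydrogen left: the exchange of isobutylamino for dimethylamino gives a 1.8-fold higher number from compound 3 to compound 4 (0.26 log units; within the scatter), and the exchange of (tert-butyl)amino for dimethylamino gives a 1.5-fold higher number from compound 2 to compound 4 (0.18 log units; within the scatter). Going to 0 hydrogen-bond donors and to 3 heavy atoms therefore leaves the number within the scatter of both compounds that keep that hydrogen. Against the plain amino group, the exchange gives a 4.5-fold higher number from compound 1 to compound 4 (0.65 log units; beyond the scatter), so compound 1 stays apart from all three alkylated compounds, and none of the four goes against this, while nothing measured alongside these numbers speaks to what lies behind them.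

Still open, from the compounds shown here alone, is whether a single methyl group on this nitrogen (methylamino), a longer chain such as diethylamino, or a cyclic amine such as pyrrolidine or morpholine would stay with compound 2, compound 3 and compound 4 or fall nearer to compound 1. All four numbers also come from this assay alone, so they say nothing about how these groups behave in any other test.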